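This account rests on a few compounds, and the source may have more. Where it says the series, first, only, none or still open, it means among the compounds named here.

Working notes on the series, read in a functional assay (trachea) with Cavia porcellus as the target; on this read-out higher numbers stand for weaker inhibition and lower numbers for stronger inhibition. Compound 1 `CC(C)=CCn1nc(-c2cccnc2)c2ccccc2c1=O` gives 1380 nM, compound 2 `COCCn1nc(-c2cccnc2)c2ccccc2c1=O` gives 9330 nM and compound 3 `O=c1c2ccccc2c(-c2cccnc2)nn1CCSc1nccs1` gives 10500 nM. Compound 3 thus sits level with compound 2, with a 1.1-fold higher number from compound 2 to compound 3 (0.05 log units; within the scatter), and on the weak side of compound 1, with a 7.6-fold higher number from compound 1 to compound 3 (0.88 log units; beyond the scatter).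

Next is compound 4 `O=C(O)Cn1nc(-c2cccnc2)c2ccccc2c1=O`, with this change: carboxy in place of ((1,3-thiazol-2-yl)sulfanyl)methyl on a saturated chain carbon bound to an aromatic nitrogen. In words, it is carboxy in place of ((1,3-thiazol-2-yl)sulfanyl)methyl on a saturated chain carbon bound to an aromatic nitrogen.

The closest evidence is the set of steps at this same place. Besides the step to compound 3, there is a 6.8-fold higher number from compound 1 to compound 2 (0.83 log units; beyond the scatter); both are modest and both go toward a higher number. Compound 2 and compound 3 carry quite different groups here yet remain level. Among the measured compounds shown here, no measured compound carries a carboxy group, so the data do not cover this change directly. In this assay, a small to modest step toward a higher number is therefore expected, and a step within the scatter remains possible. The estimated step is a 1.7-fold higher number from compound 3 to compound 4 (0.23 log units; within the scatter). For compound 4 the expected value is 18000 nM, with an estimated range from 5000 nM to 60000 nM.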

Compound 4, half-maximal inhibitory concentration: > 100000 nM
Compound 4 ended at the assay's limit (the forecaster's own chance of this, stated with the estimate: 25%); middle value at least 5.5-fold (0.74 log units) away from the limit.
By their numbers in this assay, from the lowest: compound 1; then compounds 2 and 3 (each within the scatter of the next). At a limit, above all of these: compound 4.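

In this assay compound 4 stands at > 100000 nM, which is a limit of the assay and not a number: the limit of > 100000 nM in this assay, at which 1 of the 4 values shown sits.

With carboxy at this place the steps are an at least 9.5-fold higher number from compound 3 to compound 4 (0.97 log units; beyond the scatter), an at least 10-fold higher number from compound 2 to compound 4 (1.03 log units; beyond the scatter) and an at least 72-fold higher number from compound 1 to compound 4 (1.86 log units; beyond the scatter), all beyond the scatter and all minimum sizes, since the true value of compound 4 is not known. Among the compounds shown here, the earlier compounds showed only modest steps away from 2-methylprop-1-en-1-yl and a level pair, a 1.1-fold higher number from compound 2 to compound 3 (0.05 log units; within the scatter), so this single carboxy compound is the first sign that a change on this saturated chain carbon can carry the read-out to the limit.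

For the compounds shown here, with only one carboxy compound, the series cannot separate the effect of the free carboxylic acid from that of the short carboxymethyl chain; a longer chain ending in a carboxylic acid, or the methyl ester or primary amide of compound 4, would pull these apart. Also open, on these data alone, is whether an amine at this place would read like compound 4 or like compound 2, and whether other hydrocarbon chains would match compound 1 at 1380 nM.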